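The source may hold more compounds than are shown below. What is called first, only, known or untested is meant among the compounds shown, and "the series" means these compounds.

Compound 2 `CCCCCOc1nc(C(F)(F)F)ccc1CNC(=O)Nc1cccc2[nH]c(=O)ccc12` gives 2.72 nM in an assay on HEK cells for antagonist activity at transient receptor potential cation channel subfamily V member 1 (Homo sapiens), read by FLIPR (a higher number here means a weaker inhibitor, a lower number a stronger inhibitor), the higher of the two numbers in hand; compound 1 `O=C(NCc1ccc(C(F)(F)F)nc1N1CCC(Cc2ccccc2)CC1)Nc1cccc2[nH]c(=O)ccc12` gives 1.59 nM, a gap within the scatter. Compound 3 `O=C(NCc1ccc(C(F)(F)F)nc1SC1CCCCC1)Nc1cccc2[nH]c(=O)ccc12` differs from compound 2 by cyclohexylsulfanyl in place of pentyloxy on an aromatic carbon. For the measured compounds named here, no measured step of this kind exists. Since the two measured compounds sit so close, the step from compound 2 to compound 3 in this assay is expected to be a 1.1-fold higher number from compound 2 to compound 3 (0.04 log units; within the scatter), no shift beyond the scatter in either direction. Compound 3 is thus estimated at 3 nM, with a range from 1.2 nM to 8 nM.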

Compound 3, half-maximal inhibitory concentration: 2.15 nM
Beside the measured number, compound 3's estimate is 1.4-fold (0.14 log units) above it; low and high end bracket the measured number.
By their numbers in this assay, from the lowest: compounds 1, 3 and 2 (each within the scatter of the next).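

In this assay there is a 1.3-fold lower number from compound 2 to compound 3 (0.10 log units; within the scatter) with cyclohexylsulfanyl in place of pentyloxy on the aromatic carbon next to the ring nitrogen. This position therefore takes a sulfur-linked six-membered non-aromatic ring of carbon only as well as an oxygen-linked open chain, with no shift beyond the scatter. Open, on these data alone, is whether a much smaller group such as methoxy, or a carboxylic acid, at this carbon would hold the number in this assay. No measurement at hand explains why the two groups match.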